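Swapping an Amide Linker for an Amine

A few compounds are considered here, and "the series" means these few. Any claim that something is new, unique, unknown or untested is made for them only; others in the source may bear on it.

Compound 1 `COc1cccc(CNCc2c(C(=O)O)n(Cc3ccccc3)c3cc(C)ccc23)c1`: 12500 nM
Compound 2 `COc1ccc(Cn2c(C(=O)O)c(CNC(=O)c3cccc(OC)c3)c3ccc(C)cc32)cc1`: > 50000 nM
Compound 3 `COc1cccc(CNCc2c(C(=O)O)n(Cc3ccccc3F)c3ccccc23)c1`: > 50000 nM

All three were tested in a functional assay on Bel-7402 cells (Homo sapiens) for antiproliferative activity, read by MTT assay, with a stated time of 72 h; on this read-out lower numbers stand for stronger inhibition and higher numbers for weaker inhibition. For the measured compounds named here, compound 1 is the only one with a measured number, giving 12500 nM. For compound 2 the read-out is > 50000 nM, which is a limit of the assay rather than a number. For compound 3 the read-out is likewise a limit, > 50000 nM. Compound 2 therefore stands at the limit of > 50000 nM in this assay, at which 2 of the 3 values shown sit.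

Compound 4, `COc1ccc(Cn2c(C(=O)O)c(CNCc3cccc(OC)c3)c3ccc(C)cc32)cc1`, has not yet been measured. It differs from compound 2 in one place: 3-methoxybenzyl in place of (3-methoxyphenyl)carbonyl on an amine nitrogen. Going by the values given here, no step between two measured compounds is available here, so the size of this change rests only on the pattern that compound 1 and compound 4 share the benzylamine linker while compound 2 carries the amide. The expectation is that the step from compound 2 to compound 4 moves toward stronger inhibition, by about an at least 2.5-fold lower number from compound 2 to compound 4 (0.39 log units; beyond the scatter), because compound 1 gives 12500 nM. Compound 4 is estimated at 20000 nM, within a range from 8000 nM to 50000 nM.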

Compound 4, half-maximal inhibitory concentration: 9830 nM
The estimate for compound 4 lay 2.0-fold (0.31 log units) above the measured number; the range from low to high includes it.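

In this assay, for the compounds shown here, putting 3-methoxybenzyl in place of (3-methoxyphenyl)carbonyl on the amine nitrogen gives an at least 5.0-fold lower number from compound 2 to compound 4 (0.70 log units; beyond the scatter), the first direct reading of this change between two compounds that differ in one place. The size of that step is only a lower bound, since compound 2 gives a limit of the assay and not a number: the limit of > 50000 nM in this assay, at which 2 of the 4 values shown sit. Compound 1 and compound 4 cannot be told apart, with a 1.3-fold lower number from compound 1 to compound 4 (0.10 log units; within the scatter), so methoxy in place of hydrogen on an aromatic carbon has no readable effect here.

This single pair cannot show whether the same swap would hold on another version of the core. On these data alone, how a sulfonyl group or a longer chain on that nitrogen would compare also remains open.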